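The source may report more compounds than this note shows. Statements on the series, on what has been measured and on what is new or still open speak of the compounds shown alone.

Of the compounds shown here, three built on one shared core have been measured in a physicochemical assay for solubility, read by HPLC, using the shake flask method, measured as kinetic solubility, with a stated time of 2 h, at pH 7.4; a lower number here means a less soluble compound, a higher number a more soluble compound. Compound 1 `Cc1cc(NCc2ccccn2)n2ncc(-c3ccc(N(C)C)cc3)c2n1` gives < 5000 nM, which is a limit rather than a number. Compound 2 `Cc1cc(NCc2ccccn2)n2ncc(-c3ccc(C#N)cc3)c2n1` gives < 5000 nM, again a limit. Within the data shown here, compound 3 `Cc1cc(NCc2ccccn2)n2ncc(-c3ccn(C)n3)c2n1` gives 188000 nM, the only number among the three, so it stands as the most soluble of the set. Both measured steps run towards it and are large: an at least 37-fold higher number from compound 1 to compound 3 (1.57 log units; beyond the scatter) and an at least 37-fold higher number from compound 2 to compound 3 (1.57 log units; beyond the scatter). The step between compound 1 and compound 2 cannot be read, since both sit at the limit of < 5000 nM in this assay, at which 2 of the 3 values shown sit.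

Compound 4 `Cc1cc(NCc2ccccn2)n2ncc(-c3ccc(O)cc3)c2n1` has not yet been measured. It differs from compound 3 in one place: 4-hydroxyphenyl in place of 1-methyl-1H-pyrazol-3-yl on an aromatic carbon. This runs the two measured steps backwards, from the five-membered ring to one six-membered aromatic ring of carbon only, and both of those steps were large. A large fall is therefore expected in this assay, a 31-fold lower number from compound 3 to compound 4 (1.50 log units; beyond the scatter), though the hydroxyl group is not the same as the dimethylamino or cyano groups of compound 1 and compound 2. Compound 4 is expected to give about 6000 nM, between 1500 nM and 30000 nM, and may well come back as a limit.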

Compound 4, solubility: 10900 nM
Compound 4: middle estimate off by 1.8-fold (0.26 log units), on the low side, and the stated range covers the measured number.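

In this assay, a six-membered aromatic ring of carbon only now gives a readable number at this position, and the fall on leaving 1-methyl-1H-pyrazol-3-yl remains large: a 17-fold lower number from compound 3 to compound 4 (1.24 log units; beyond the scatter). The group carried on that six-membered ring also changes the reading: hydroxy in place of cyano gives an at least 2.1-fold higher number from compound 2 to compound 4 (0.33 log units; beyond the scatter), and hydroxy in place of dimethylamino gives an at least 2.1-fold higher number from compound 1 to compound 4 (0.33 log units; beyond the scatter), so these rings do not all sit at the limit. Those two steps fix only a smallest size, not a true one: the limit of < 5000 nM in this assay, at which 2 of the 4 values shown sit.

On these data alone, whether a carboxylic acid or a longer chain ending in an amine, set in place of the hydroxy group, would read nearer compound 3 or compound 4 stays open. As far as these compounds go, how much of the gap between those two compounds belongs to the ring itself, and how much to its hydroxy group, also stays open.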